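This account rests on a few compounds, and the source may have more. Where it says the series, first, only, none or still open, it means among the compounds named here.

In a functional assay on HT-29 cells (Homo sapiens) for cytotoxicity, read by MTT assay, with a stated time of 72 h (on this read-out lower numbers stand for stronger inhibition and higher numbers for weaker inhibition), the measured compounds are:

Compound 1 `COc1ccc(OC)c(/C=N/NC(=O)Nc2ccc(Oc3ccnc(-c4nncn4CCN(C)C)c3)c(F)c2)c1`: 2070 nM
Compound 2 `CN(C)CCn1cnnc1-c1cc(Oc2ccc(NC(=O)N/N=C/c3ccc(O)c(Br)c3)cc2F)ccn1`: 450 nM
Compound 3 `CN(C)CCn1cnnc1-c1cc(Oc2ccc(NC(=O)N/N=C/c3ccc(F)cc3)cc2F)ccn1`: 1370 nM

Compound 3 stands second highest of these three numbers; the step of a 1.5-fold lower number from compound 1 to compound 3 (0.18 log units; within the scatter) lies within the scatter, whereas a 3.0-fold higher number from compound 2 to compound 3 (0.48 log units; beyond the scatter) lies beyond it. Compound 4 `CN(C)CCn1cnnc1-c1cc(Oc2ccc(NC(=O)N/N=C/c3ccccc3)cc2F)ccn1` differs from compound 3 by hydrogen in place of fluoro on an aromatic carbon. Among the compounds with values here, none of the measured steps removes a fluoro alone; each exchanges the whole aryl group, and even the exchange of 2,5-dimethoxyphenyl for 4-fluorophenyl stayed within the scatter. A change as small as this is therefore expected to give no step beyond the scatter, the estimated step being a 1.0-fold higher number from compound 3 to compound 4 (0.01 log units; within the scatter). Compound 4 is estimated at 1400 nM, within a range of 700 nM to 2800 nM.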

Compound 4, half-maximal inhibitory concentration: 1120 nM
Compound 4: the middle estimate sits 1.3-fold (0.10 log units) above what was measured; measured number inside the range.
By their numbers in this assay, from the lowest: compound 2; then compounds 4, 3 and 1 (each within the scatter of the next).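

In this assay, hydrogen in place of fluoro on this aromatic carbon, para to a large group, gives a step within the scatter (a 1.2-fold lower number from compound 3 to compound 4 (0.09 log units; within the scatter)). The unsubstituted phenyl of compound 4 also stays within the scatter of the 2,5-dimethoxyphenyl of compound 1 (a 1.8-fold lower number from compound 1 to compound 4 (0.27 log units; within the scatter)). The 3-bromo-4-hydroxyphenyl of compound 2 remains set apart, with a step beyond the scatter (a 2.5-fold higher number from compound 2 to compound 4 (0.40 log units; beyond the scatter)).

Nothing measured here accounts for these steps. On these data alone, whether an amine or a carboxylic acid on this aromatic carbon would leave the number within the scatter stays open.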